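Benzylselanyl in place of methylsulfanyl across two cores

This account rests on a few compounds, and the source may have more. Where it says the series, first, only, none or still open, it means among the compounds named here.

Compound 1 `O=C(/N=C(/NC(=O)c1cccs1)[Se]Cc1ccccc1)c1cccs1`: in a functional assay on MCF7 cells (Homo sapiens) for cytotoxicity, read by MTT assay, with a stated time of 72 h (a higher number here means a weaker inhibitor of growth, a lower number a stronger inhibitor of growth), compound 1 gives > 100000 nM, which is a limit of the assay.
Compound 2 `CS/C(=N\C(=O)c1cccs1)NC(=O)c1cccs1`: in this assay compound 2 gives 89000 nM.
Compound 3 `CS/C(=N\C(=O)c1cnc2ccccc2c1)NC(=O)c1cnc2ccccc2c1`: in this assay compound 3 gives > 100000 nM, which is a limit of the assay.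

Within the data shown here, the one measured step is a group of 8 heavy atoms (7 carbon, 1 selenium; one six-membered aromatic ring of carbon only) in place of a group of 2 heavy atoms (1 carbon, 1 sulfur; no ring), on a carbon with a double bond to nitrogen; it gave an at least 1.1-fold higher number from compound 2 to compound 1 (0.05 log units; that floor lies within the scatter). Because (the limit of > 100000 nM in this assay, at which 2 of the 3 values shown sit), the size of this step is bounded only from one side, and nothing more can be read from it.

Compound 3 carries a different core from compound 2; the difference between the two cores is not broken down here. Compound 4 `O=C(/N=C(/NC(=O)c1cnc2ccccc2c1)[Se]Cc1ccccc1)c1cnc2ccccc2c1` is not yet measured. It differs from compound 3 by a group of 8 heavy atoms (7 carbon, 1 selenium; one six-membered aromatic ring of carbon only) in place of a group of 2 heavy atoms (1 carbon, 1 sulfur; no ring), on a carbon with a double bond to nitrogen, the same change as that from compound 2 to compound 1, made on the other core.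

With compound 3 already at a limit of the assay, and with the measured step from compound 2 to compound 1 not having moved the number beyond the scatter, compound 4 is expected to remain at or past that limit, an estimated step that the limit leaves unreadable from compound 3 to compound 4. For compound 4 in this assay the expected value is 150000 nM, between 60000 nM and 500000 nM.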

Compound 4, concentration for total growth inhibition: > 100000 nM
Compound 4 was reported as a limit; the forecaster's own chance of this, stated with the estimate: 85%; the middle value does not contradict the limit.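

The step from compound 3 to compound 4 cannot be read, because both values are limits of the assay: the limit of > 100000 nM in this assay, at which 3 of the 4 values shown sit.

The compounds shown leave open how far replacing methylsulfanyl with the selenium-containing group moves the number on either core, and how the two cores compare with each other.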